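The source may hold more compounds than are shown below. What is called first, only, known or untested is meant among the compounds shown, and "the series" means these compounds.

Measured so far:
- Compound 1 `C[C@H](NC(=O)C1CCOCC1)c1ccc(NC(=O)N2CC(c3cccnc3)C2)cc1` gives 380000 nM
- Compound 2 `CCC(=O)N[C@@H](C)c1ccc(NC(=O)N2CC(c3cccnc3)C2)cc1` gives 700000 nM

Among the compounds with values here, in a physicochemical assay for solubility, read by LC-MS, in phosphate buffer, with a stated time of 24 h, at pH 6.8 (a higher number here means a more soluble compound, a lower number a less soluble compound), compound 1 gives 380000 nM and stands within the scatter of the only other number known. Compound 3 `C[C@H](NC(=O)C1CCOCC1)c1ccc(NC(=O)N2CC(c3cncc(N)c3)C2)cc1` differs from compound 1 by a single change: amino in place of hydrogen on an aromatic carbon turns pyridin-3-yl to 5-aminopyridin-3-yl. Within the data shown here, the one measured step is a 1.8-fold higher number from compound 1 to compound 2 (0.27 log units; within the scatter) and comes from ethyl in place of oxan-4-yl on a carbonyl carbon. That step lies within the scatter and sits at a different place, so no measurement speaks directly to amino in place of hydrogen on an aromatic carbon. From the compounds shown here alone, no step beyond the scatter is therefore expected in this assay and the direction remains open. The estimated step is a 1.3-fold lower number from compound 1 to compound 3 (0.10 log units; within the scatter) and the range is kept wide. Compound 3 is estimated at 300000 nM with an expected range from 100000 nM to 800000 nM in this measurement.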

Compound 3, solubility: 440000 nM
The estimate for compound 3 lay 1.5-fold (0.17 log units) below the measured number, within the range that was stated.
By their numbers in this assay, from the lowest: compounds 1, 3 and 2 (each within the scatter of the next).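

In this assay, amino in place of hydrogen on an aromatic carbon, the change that turns pyridin-3-yl to 5-aminopyridin-3-yl, gives a 1.2-fold higher number from compound 1 to compound 3 (0.06 log units; within the scatter). This adds a reading at a second place in compound 1, two atoms from the ring nitrogen, to the one on the carbonyl carbon, where the step is a 1.8-fold higher number from compound 1 to compound 2 (0.27 log units; within the scatter), so among these compounds a single change at either place stays within the scatter. Nothing measured here offers an account of this result.

From the compounds shown here alone, whether a larger group at this ring position, such as a dimethylamino group or a carboxylic acid, would also stay within the scatter remains open. So does whether amino at this position would give the same reading with ethyl on the carbonyl carbon, as in compound 2.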